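Moving one chlorine: from compound 2 to compound 4

The source may hold more compounds than are shown below. What is called first, only, known or untested is meant among the compounds shown, and "the series" means these compounds.

Compound 1 `CC(C)[C@H](NC(=O)c1ccc(Cl)cc1O)C(=O)Nc1ccc(Br)cc1` gives > 10000 nM
Compound 2 `C[C@H](NC(=O)c1cc(Cl)ccc1O)C(=O)Nc1ccc(C(F)(F)F)cc1` gives > 12500 nM
Compound 3 `C[C@H](NC(=O)c1cc(Cl)ccc1O)C(=O)Nc1cccc(Cl)c1` gives > 10000 nM

These three compounds were tested in a functional assay on MCF7 cells (Homo sapiens) for cytotoxicity, with a stated time of 72 h (a higher number here means a weaker inhibitor, a lower number a stronger inhibitor), and each result is a limit of the assay, not a number. No order among them can be read from such results. Compound 2 has no number of its own and stands at the limit of > 12500 nM in this assay, at which 1 of the 3 values shown sits; the result is a limit.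

Compound 4 `C[C@H](NC(=O)c1ccc(Cl)cc1O)C(=O)Nc1ccc(C(F)(F)F)cc1` has not yet been measured. It has the same atoms as compound 2, joined differently: 4-chloro-2-hydroxyphenyl in place of 5-chloro-2-hydroxyphenyl on a carbonyl carbon. The rest of the structure stays the same.

Among the measured compounds shown here, no pair of measured compounds differs in one place only, so the size of this step can only be expected. Compound 1 also carries 4-chloro-2-hydroxyphenyl and gives only a limit (> 10000 nM). Compound 3 carries 5-chloro-2-hydroxyphenyl and also gives only a limit (> 10000 nM). On that basis, no step beyond the usual scatter is expected in this assay in either direction. The expected step is a number no higher from compound 2 to compound 4 (the limit leaves the size open) and this is an estimate only. For compound 4 the estimated value is 12500 nM with an expected range from 6000 nM to 25000 nM and the assay may well report only a limit.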

Compound 4, half-maximal inhibitory concentration: > 12500 nM
Compound 4: a limit, no number (the forecaster's own chance of this, stated with the estimate: 85%); the middle value lies on the limit itself.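

No step can be read between compound 2 and compound 4, since each gives only a limit and not a number: the limit of > 12500 nM in this assay, at which 2 of the 4 values shown sit.

The compounds shown leave open whether 4-chloro-2-hydroxyphenyl and 5-chloro-2-hydroxyphenyl differ at all in this assay, and which change to the shared structure would give a readable number there.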